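Replacing an Aryl Group by a Benzyl Group on the Ring Nitrogen

This account rests on a few compounds, and the source may have more. Where it says the series, first, only, none or still open, it means among the compounds named here.

Compound 3 `Cc1ccc(-n2cc(CSC(=S)N3CCN(C(=O)OC(C)(C)C)CC3)nn2)cc1` stands second highest of the three numbers in a functional assay on MGC-803 cells (Homo sapiens) for inhibition, read by MTT assay, with a stated time of 72 h (a higher number here means a weaker inhibitor, a lower number a stronger inhibitor), giving 48300 nM. Its nearest neighbour is compound 2 `O=C(OCc1ccccc1)N1CCN(C(=S)SCc2cn(Cc3ccc(Cl)cc3)nn2)CC1`, which gives 31300 nM, while compound 1 `COc1ccc(-n2cc(CSC(=S)N3CCN(C(=O)OC(C)(C)C)CC3)nn2)cc1` gives 87300 nM; both lie within the scatter of compound 3. For the measured compounds named here, the only single-point step measured so far, a 1.8-fold lower number from compound 1 to compound 3 (0.26 log units; within the scatter), concerned a substituent on the aromatic ring and not the ring nitrogen. Compound 4 `CC(C)(C)OC(=O)N1CCN(C(=S)SCc2cn(Cc3ccc(Cl)cc3)nn2)CC1` carries 4-chlorobenzyl in place of 4-methylphenyl on an aromatic nitrogen. Going by the values given here, no measured step covers this exchange; compound 2 already bears the 4-chlorobenzyl group but differs from compound 4 elsewhere, so its value serves only as a rough guide. The step of a 1.3-fold lower number from compound 3 to compound 4 (0.10 log units; within the scatter) is therefore expected to stay within the scatter. The estimate for compound 4 is 38000 nM, between 15000 nM and 95000 nM.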

Compound 4, half-maximal inhibitory concentration: 9790 nM
Compound 4: the middle estimate sits 3.9-fold (0.59 log units) above what was measured; measured number outside the range, below it.
By their numbers in this assay, from the lowest: compound 4; then compounds 2, 3 and 1 (each within the scatter of the next, the first and the last beyond it).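

In this assay the exchange on the aromatic nitrogen gives a step beyond the scatter, a 4.9-fold lower number from compound 3 to compound 4 (0.69 log units; beyond the scatter), and the 4-methoxyphenyl comparison agrees, an 8.9-fold lower number from compound 1 to compound 4 (0.95 log units; beyond the scatter), so this position responds where the methyl for methoxy step on the aromatic ring did not. With 4-chlorobenzyl held fixed, tert-butyl in place of benzyl on the oxygen next to a carbonyl group also gives a step beyond the scatter, a 3.2-fold lower number from compound 2 to compound 4 (0.50 log units; beyond the scatter), so a second place matters too. Nothing available accounts for either change.

The exchange alters the link to the ring nitrogen and brings in chlorine together, and the compounds shown do not separate the two. On these data alone, how an unsubstituted benzyl or a longer chain such as 2-phenylethyl would read at this position remains open.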